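The source may hold more compounds than are shown below. What is called first, only, known or untested is meant among the compounds shown, and "the series" means these compounds.

Among the measured compounds shown here, compound 1 `CC1CCN(C2CCN(S(=O)(=O)c3cccnc3F)CC2)CC1` is one of two compounds measured in an ADME assay on HCT-116 cells (Homo sapiens) for cytotoxicity, read by CellTiter-Glo, with a stated time of 72 h (on this read-out lower numbers stand for stronger inhibition and higher numbers for weaker inhibition), and in it compound 1 gives > 10000 nM, which is a limit of the assay rather than a number; (the limit of > 10000 nM in this assay, at which 1 of the 2 values shown sits). Compound 2 `Cc1cc(S(=O)(=O)N2CCC(N3CCC(C)CC3)CC2)c(Cl)cc1Cl` is likewise known only by a limit in this assay, where compound 2 gives > 5000 nM; (the limit of > 5000 nM in this assay, at which 1 of the 2 values shown sits). For the measured compounds named here, compound 1 therefore stands at a limit, with no numerical value of its own, and no step between measured compounds can be drawn. Compound 3 `CC1CCN(C2CCN(S(=O)(=O)c3cccc(Br)c3)CC2)CC1` has not yet been measured in this assay. It differs from compound 1 by 3-bromophenyl in place of 2-fluoropyridin-3-yl on a sulfonyl sulfur. With both measured compounds sitting at limits, the step of a number no higher from compound 1 to compound 3 (the limit leaves the size open) is expected to be none beyond the usual scatter, and the result is most likely again a limit. For compound 3 the expected value in this assay is 10000 nM, within a range from 3000 nM to 30000 nM.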

Compound 3, half-maximal inhibitory concentration: > 5000 nM
Compound 3 gave a limit, no number; the forecaster's own chance of this, stated with the estimate: 80%; the middle value is on the limit's open side.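

Among the compounds shown here, compound 1 and compound 3 are each known only by a limit, and no step between them can be read. The compounds shown leave open whether 3-bromophenyl in place of 2-fluoropyridin-3-yl on a sulfonyl sulfur changes the read-out at all in this assay.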